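The compounds below may be only part of what the source reports. "The series", "measured", "known", "first", "only" and "open" are said of these compounds alone.

Measured compounds:
compound 1 `CC1(C)[C@H](C(=O)OCOC(=O)CCCCC(=O)OCc2ccccc2)N2C(=O)C[C@H]2S1(=O)=O` — 1 h
compound 2 `CC1(C)[C@H](C(=O)OCOC(=O)CC(=O)O)N2C(=O)C[C@H]2S1(=O)=O` — 0.8 h
compound 3 `CC1(C)[C@H](C(=O)OCOC(=O)CCCC(=O)O)N2C(=O)C[C@H]2S1(=O)=O` — 1.1 h

All three values come from an ADME assay on the whole organism for pharmacokinetics, with Rattus norvegicus as the target; a higher number here means that the compound lasts longer, a lower number that the compound disappears faster. Compound 2 sits at the low end of the three numbers, yet its gaps to compound 1 and to compound 3 both lie within the scatter, so the three compounds are not separable in this assay. Compound 4 `CC1(C)[C@H](C(=O)OCOC(=O)CCCCC(=O)O)N2C(=O)C[C@H]2S1(=O)=O` differs from compound 2 in one place: 3-carboxypropyl in place of carboxy on a saturated chain carbon bound to a carbonyl carbon. Among the compounds with values here, two measured steps bear on this change. Lengthening the acid chain gave a 1.4-fold higher number from compound 2 to compound 3 (0.14 log units; within the scatter), and exchanging the chain end gave a 1.1-fold higher number from compound 1 to compound 3 (0.04 log units; within the scatter); neither left the scatter. The half-life of compound 4 is therefore expected to stay close to that of compound 2, with a 1.3-fold higher number from compound 2 to compound 4 (0.10 log units; within the scatter). The estimate for compound 4 is 1 h, within 0.6 h to 1.7 h.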

Compound 4, half-life: 1 h
Estimate against measurement, compound 4: no gap at the digits printed; the range from low to high includes it.
By their numbers in this assay, from the lowest: compounds 2, 1, 4 and 3 (each within the scatter of the next).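

In this assay, 3-carboxypropyl in place of carboxy on a saturated chain carbon bound to a carbonyl carbon gives a 1.3-fold higher number from compound 2 to compound 4 (0.10 log units; within the scatter), so this change also stays within the scatter. Carboxymethyl in place of carboxy gives a 1.1-fold lower number from compound 3 to compound 4 (0.04 log units; within the scatter), and hydrogen in place of benzyl on an oxygen next to a carbonyl group gives no change at the digits printed from compound 1 to compound 4 (within the scatter), so the acid and its benzyl ester on this same chain cannot be told apart. No measurement given here explains this flat result. The compounds shown leave open whether an amine in place of the carboxylic acid at the chain end, or a ring within the chain, would carry the half-life beyond the scatter.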